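The source may report more compounds than this note shows. Statements on the series, on what has been measured and on what is new or still open speak of the compounds shown alone.

Compound 1 `Nc1scc(CN2CCN(c3ccc(Cl)cc3Cl)CC2)c1C(=O)c1ccc(Cl)cc1` is the reference point of the series. In an assay on CHO cells for displacement of a labelled ligand from adenosine receptor A3 (Homo sapiens), read by scintillation counting, with a stated time of 120 min, tested at 10 uM (on this read-out lower numbers stand for less inhibition and higher numbers for more inhibition at the one concentration tested (going by the name of the read-out)), compound 1 gives 0%, the lowest of the three measured numbers, although all three sit within the usual scatter of one another. Compound 2 `Nc1scc(CN2CCN(c3ccc(Cl)cc3F)CC2)c1C(=O)c1ccc(Cl)cc1` gives 1% in this assay, and compound 3 `Nc1scc(CN2CCN(C3CCCC3)CC2)c1C(=O)c1ccc(Cl)cc1` gives 3%. Compound 4 `Nc1scc(CN2CCN(c3c(F)cc(F)cc3F)CC2)c1C(=O)c1ccc(Cl)cc1`, not yet measured, differs from compound 1 as follows: 2,4,6-trifluorophenyl in place of 2,4-dichlorophenyl on an amine nitrogen in a ring. Among the compounds with values here, two measured steps bear on this change: a number 1 percentage points higher from compound 1 to compound 2 (within the scatter) and a number 3 percentage points higher from compound 1 to compound 3 (within the scatter). Neither moved this assay beyond the scatter, so no step beyond the scatter is expected here either, a number 2 percentage points higher from compound 1 to compound 4 (within the scatter). Compound 4 is accordingly estimated at 2% in this assay, with a range from 0% to 12%.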

Compound 4, a percentage reported as inhibition, at one concentration (the size of the read-out at that concentration, not a potency): 0%
Estimate against measurement, compound 4: 2 percentage points above; low and high end bracket the measured number.
By their numbers in this assay, from the lowest: compounds 1, 4, 2 and 3 (each within the scatter of the next).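

With 2,4,6-trifluorophenyl on the amine nitrogen in the ring, the read-out in this assay stays flat against each earlier group: 2,4-dichlorophenyl (no change at the digits printed from compound 1 to compound 4 (within the scatter)), 4-chloro-2-fluorophenyl (a number 1 percentage points lower from compound 2 to compound 4 (within the scatter)) and cyclopentyl (a number 3 percentage points lower from compound 3 to compound 4 (within the scatter)). An aryl group carrying fluorine alone therefore joins the chlorine-bearing aryl groups and the cyclopentyl group, with all of these compounds within the scatter of one another. No available data explain this flat result. Still open, from the compounds shown here alone, is whether a carboxylic acid, a primary amine or a longer alkyl chain at this nitrogen would change the read-out. Changes elsewhere on the shared core also remain open.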